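A few compounds are considered here, and "the series" means these few. Any claim that something is new, unique, unknown or untested is made for them only; others in the source may bear on it.

Series in a functional assay on T98G cells (Homo sapiens) for cytotoxicity, read by MTT assay, with a stated time of 48 h; on this read-out lower numbers stand for stronger inhibition and higher numbers for weaker inhibition:
- compound 1 `C/C(=N\NC(=S)Nc1ccc(Cl)cc1)c1ccccn1`: 5.9 nM
- compound 2 `C/C(=N\NC(=S)Nc1ccc([N+](=O)[O-])cc1)c1ccccn1`: 140 nM

Compound 2 holds the higher of the two numbers. Within the data shown here, the only measured step, a 24-fold higher number from compound 1 to compound 2 (1.38 log units; beyond the scatter), is nitro in place of chloro on an aromatic carbon, so it says nothing about a drawn configuration. Compound 3 `CC(=NNC(=S)Nc1ccc([N+](=O)[O-])cc1)c1ccccn1` differs from compound 2 only in the drawing: the two compounds have the same atoms and bonds; at least one stereo element is drawn with a configuration in one of them and without one in the other: 1 of 1 stereo elements differ; a double bond is drawn E in compound 2 and without a configuration in compound 3. With the same atoms and bonds as compound 2 at 140 nM, no step beyond the scatter is expected in this assay. The expected step is no change at the digits printed from compound 2 to compound 3 (within the scatter). For compound 3 the estimated value is 140 nM, with an expected range of 65 nM to 300 nM.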

Compound 3, half-maximal inhibitory concentration: 140 nM
Beside the measured number, compound 3's estimate shows no gap at the digits printed; low and high end bracket the measured number.
By their numbers in this assay, from the lowest: compound 1; then compounds 2 and 3 (each within the scatter of the next).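

In this assay the double bond, drawn E or without a configuration, shows no change at the digits printed from compound 2 to compound 3 (within the scatter), so this first reading at the double bond adds no separable effect of the drawing, unlike the step between the chloro and nitro groups. The comparison rests on a single difference: the fact that one of compounds 2 and 3 is drawn with a defined configuration and the other without, at the place where they differ.

The drawings cannot tell whether compound 3 has the same geometry as compound 2 or is a mixture. Also open, from the compounds shown here alone, is how an amine or a carboxylic acid on that aromatic carbon would compare with chloro and nitro.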